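Pyridin-2-yl for phenyl on two cores, Chk2

The source may hold more compounds than are shown below. What is called first, only, known or untested is meant among the compounds shown, and "the series" means these compounds.

Measured so far:
compound 1 `Cn1nc(N)c2c(=O)[nH]c(-c3ccccc3)cc21` gives 16%
compound 2 `Cn1nc(N)c2c(=O)[nH]c(-c3ccccn3)cc21` gives 25%
compound 3 `Nc1c2c(=O)[nH]c(-c3ccccc3)cc2nn1-c1ccccc1` gives -8%

All three were run in an assay on isolated protein for inhibition of serine/threonine-protein kinase Chk2 (Homo sapiens), read by mobility shift assay, tested at 30 uM; on this read-out higher numbers stand for more inhibition at the one concentration tested (going by the name of the read-out) and lower numbers for less inhibition. Compound 1 and compound 2 share a core and differ in one place: pyridin-2-yl in place of phenyl on an aromatic carbon. The step from the first to the second is a number 9 percentage points higher from compound 1 to compound 2 (within the scatter), so the two numbers cannot be told apart. Compound 3 carries a different core; how the two cores differ is not broken down here. In this assay compound 3 stands lowest, with compound 1 and compound 2 each beyond the scatter above it.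

Compound 4 `Nc1c2c(=O)[nH]c(-c3ccccn3)cc2nn1-c1ccccc1` is not yet measured. It differs from compound 3 in the same way compound 2 differs from compound 1: pyridin-2-yl in place of phenyl on an aromatic carbon. The place of the change is the same in both pairs. Since the earlier step of a number 9 percentage points higher from compound 1 to compound 2 (within the scatter) stayed within the scatter, the expected step from compound 3 to compound 4 is of about the same size, a number 9 percentage points higher from compound 3 to compound 4 (within the scatter). Compound 4 is therefore estimated at 1%, between -14% and 16%, resting on the value of compound 3 -8% and that one earlier step.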

Compound 4, a percentage reported as inhibition, at one concentration (the size of the read-out at that concentration, not a potency): 3%
Compound 4: the middle estimate sits 2 percentage points below what was measured, within the range that was stated.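

In this assay, pyridin-2-yl in place of phenyl on an aromatic carbon gives a number 11 percentage points higher from compound 3 to compound 4 (beyond the scatter). Set beside the earlier step on the other core, the change carries over with no difference that can be told apart: the same change on two cores in this assay, a number 9 percentage points higher (within the scatter) from compound 1 to compound 2 and a number 11 percentage points higher (beyond the scatter) from compound 3 to compound 4, 2 percentage points apart, within the scatter of two such steps. Among these compounds, this rests on only two pairs read at one concentration, with compound 4 at 3%, so it gives no potency and does not show that the step would hold on any core other than these two.

The compounds shown carry only phenyl and pyridin-2-yl at this place, so the outcome with a pyridin-3-yl, or with a phenyl bearing a carboxylic acid or a longer amine chain, remains open. Also open, on these data alone, is whether the step would keep its size on a compound reading much higher in this assay.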